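Lengthening the Nitrooxy-Bearing Ester Chain: An Expected Potency

The source may hold more compounds than are shown below. What is called first, only, known or untested is meant among the compounds shown, and "the series" means these compounds.

Measured so far:
compound 1 `COc1cc(/C=C/C(=O)OC/C=C/CO[N+](=O)[O-])ccc1O`: 2360 nM
compound 2 `COc1cc(/C=C/C(=O)OCCCO[N+](=O)[O-])ccc1O`: 29500 nM
compound 3 `COc1cc(/C=C/C(=O)OC(C)C)ccc1O`: a limit of the assay, > 50000 nM

All three were tested in a functional assay on LOX IMVI cells (Homo sapiens) for cytotoxicity, read by resazurin assay, with a stated time of 72 h; on this read-out lower numbers stand for stronger inhibition and higher numbers for weaker inhibition. Compound 2, with 29500 nM, stands highest of the two plain numbers shown. Its nearest neighbour is compound 1, which gives 2360 nM; the gap between them is a 13-fold higher number from compound 1 to compound 2 (1.10 log units; beyond the scatter). For compound 3 the assay reports only a limit, > 50000 nM.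

Compound 4 `COc1cc(/C=C/C(=O)OCCCCCCO[N+](=O)[O-])ccc1O` has not yet been measured. It differs from compound 2 in one place: 3-(nitrooxy)propyl in place of nitrooxy on a saturated chain carbon, three bonds along the chain from an oxygen next to a carbonyl group. The nitrooxy group is kept and the saturated chain carrying it is made longer.

Among the compounds with values here, two measured steps bear on this. The first, a 13-fold higher number from compound 1 to compound 2 (1.10 log units; beyond the scatter), shows that changing the chain that carries the nitrooxy group can move the number a long way. The second, an at least 1.6-fold higher number from compound 2 to compound 3 (0.22 log units; that floor lies within the scatter), ends at a limit and settles little. Within the data shown here, a move back toward lower numbers is expected for compound 4, though the single informative step leaves the size uncertain. The step of a 3.0-fold lower number from compound 2 to compound 4 (0.47 log units; beyond the scatter) is expected. Compound 4 is estimated at 10000 nM, between 2500 nM and 40000 nM.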

Compound 4, half-maximal inhibitory concentration: > 50000 nM
Compound 4: only a limit was reported (the forecaster's own chance of this, stated with the estimate: 15%); middle value at least 5.0-fold (0.69 log units) from the limit.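

In this assay compound 4 gives only a limit of the assay, > 50000 nM. The change can therefore be read only as a floor, an at least 1.6-fold higher number from compound 2 to compound 4 (0.22 log units; that floor lies within the scatter), so compound 2 and compound 4 cannot be put in order, although the longer chain clearly did not bring the number down to a measured value. Keeping the nitrooxy group on a saturated chain thus does not by itself secure a measurable number at this position, and the end of the assay's range now restricts what can be read: the limit of > 50000 nM in this assay, at which 2 of the 4 values shown sit.

From the compounds shown here alone, whether a 4-(nitrooxy)butyl or 5-(nitrooxy)pentyl chain would give a measured value remains open. So does the effect of a hexyl chain carrying the double bond of compound 1, or a hydroxyl group in place of nitrooxy.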